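The source may report more compounds than this note shows. Statements on the series, on what has been measured and on what is new or still open speak of the compounds shown alone.

Measured compounds:
Compound 1 `O=C(Nc1ccccc1O)C1CCc2ccccc2N1C(=O)c1ccccc1Cl`: 60000 nM
Compound 2 `O=C(Nc1ccccc1C(F)(F)F)C1CCc2ccccc2N1C(=O)c1cccc(Cl)c1`: 729 nM

In a functional assay on PC-3 cells (Homo sapiens) for cytotoxicity, read by sulforhodamine B assay, with a stated time of 72 h (on this read-out higher numbers stand for weaker inhibition of growth and lower numbers for stronger inhibition of growth), compound 1 gives 60000 nM, while compound 2 gives 729 nM. Compound 2 thus stands at the lowest of the two numbers, and the gap up to compound 1 lies well beyond the usual scatter of this assay. The two compounds differ in more than one place, so no single change can be read from that gap.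

Compound 3 `O=C(Nc1ccccc1O)C1CCc2ccccc2N1C(=O)c1cccc(Cl)c1` has not yet been measured. It is reached from compound 2 by one change: hydroxy in place of trifluoromethyl on an aromatic carbon. Compound 3 therefore shares the hydroxy group with compound 1 and the rest of its structure with compound 2.

Going by the values given here, the account has no measured step for this exact change. Among the compounds with values here, the only guide is that compound 1, which carries the same hydroxy group, gives 60000 nM, far up from compound 2. On that basis compound 3 is expected to lose ground in this assay, with a step of a 16-fold higher number from compound 2 to compound 3 (1.22 log units; beyond the scatter) that goes beyond the scatter. The estimate for compound 3 is 12000 nM, with a range from 2500 nM to 60000 nM.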

Compound 3, concentration for 50% growth inhibition: 23300 nM
The estimate for compound 3 lay 1.9-fold (0.29 log units) below the measured number; the range from low to high includes it.
By their numbers in this assay, from the lowest: compound 2; then compound 3; then compound 1.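

In this assay, hydroxy in place of trifluoromethyl on an aromatic carbon, ortho to a large group, now has a step of its own: a 32-fold higher number from compound 2 to compound 3 (1.50 log units; beyond the scatter) is large, and compound 2 is the only one of the three that carries trifluoromethyl. Going by these compounds alone, the other difference between the earlier compounds can now be read on its own as well, with the hydroxy group held constant: 3-chlorophenyl in place of 2-chlorophenyl on a carbonyl carbon gives a 2.6-fold lower number from compound 1 to compound 3 (0.41 log units; beyond the scatter), a modest step that is still beyond the scatter. The change of group on the 2-substituted phenyl therefore moves the number much further than the move of the chlorine does, though nothing here explains why.

From the compounds shown here alone, whether another group at this place, such as an amine, a methoxy group or a single fluorine atom, would fall nearer compound 2 or nearer compound 3 stays open. The step between the two chlorophenyl groups is shown only with hydroxy present, so its size alongside trifluoromethyl also stays open.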